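Cytotoxicity on Colon Cells: From Amide Compound 2 to 3

The source may report more compounds than this note shows. Statements on the series, on what has been measured and on what is new or still open speak of the compounds shown alone.

Measured compounds:
Compound 1 `COc1ccc(OC)c(NC(=O)c2cccc(/C=C3\CC(=O)N(c4ccccc4)C3=O)c2)c1`: > 100000 nM
Compound 2 `O=C(NCC1CCCCC1)c1cccc(/C=C2\CC(=O)N(c3ccccc3)C2=O)c1`: > 100000 nM

In an ADME assay on NCM460 cells (Homo sapiens) for cytotoxicity, read by MTT assay, with a stated time of 72 h (a higher number here means a weaker inhibitor, a lower number a stronger inhibitor), compound 1 gives only > 100000 nM, which is a limit of the assay and not a number. Compound 2 likewise gives only > 100000 nM, again a limit. The step that the two limits leave unreadable from compound 1 to compound 2 therefore cannot be read. For the measured compounds named here, compound 2 stands at the limit, as does the one other value shown (the limit of > 100000 nM in this assay, at which 2 of the 2 values shown sit).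

Compound 3 `CSc1cccc(NC(=O)c2cccc(/C=C3\CC(=O)N(c4ccccc4)C3=O)c2)c1` differs from compound 2 by 3-(methylsulfanyl)phenyl in place of cyclohexylmethyl on an amide-type nitrogen. Going by the values given here, no measured step has a readable size, so the change itself offers no direction to lean on. Because both measured compounds sit at the limit (the limit of > 100000 nM in this assay, at which 2 of the 2 values shown sit), compound 3 is expected to sit there too, with an expected step that the limit leaves unreadable from compound 2 to compound 3 that amounts to none beyond the scatter. The estimate for compound 3 is 150000 nM, ranging from 50000 nM to 500000 nM.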

Compound 3, half-maximal inhibitory concentration: > 100000 nM
Compound 3: no number, only a limit; the forecaster's own chance of this, stated with the estimate: 85%; the middle value does not contradict the limit.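

Compound 3 gives > 100000 nM, which is a limit of the assay and not a number. For the compounds shown here, no step to compound 3 from compound 1 or compound 2 can be read. The compounds shown leave open whether changing the group on the amide nitrogen alters the result in this assay.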